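The source may hold more compounds than are shown below. What is called first, only, known or untested is meant among the compounds shown, and "the series" means these compounds.

Measured so far in an assay on membranes from lung (Cavia porcellus) for binding affinity to cysteinyl leukotriene receptor (Homo sapiens); a lower number here means a stronger inhibitor, a higher number a weaker inhibitor:
Compound 1 `O=C(O)CC1CCC(c2ccc(OCc3ccc4ccccc4n3)cc2)C1` gives 22 nM.
Compound 2 `O=C(O)CCCOc1ccc(OCc2ccc3ccccc3n2)cc1` gives 1200 nM.
Compound 3 `CC(CCC(=O)O)Cc1ccc(OCc2ccc3ccccc3n2)cc1` gives 43 nM.

Compound 3 sits second of the three numbers. Its nearest neighbour is compound 1, reached by a 2.0-fold higher number from compound 1 to compound 3 (0.29 log units; within the scatter), so the two cannot be told apart. Compound 2 stands far away: the step of a 28-fold lower number from compound 2 to compound 3 (1.45 log units; beyond the scatter) is large, as is a 55-fold higher number from compound 1 to compound 2 (1.74 log units; beyond the scatter).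

Compound 4 `O=C(O)C1CCC(c2ccc(OCc3ccc4ccccc4n3)cc2)C1` has not been measured. Compared with compound 3 the change is 3-carboxycyclopentyl in place of 4-carboxy-2-methylbutyl on an aromatic carbon. Going by the values given here, two measured steps bear on it. The step of a 2.0-fold higher number from compound 1 to compound 3 (0.29 log units; within the scatter) shows that a 3-(carboxymethyl)cyclopentyl and a 4-carboxy-2-methylbutyl chain give numbers within the scatter, so closing the chain into a five-membered carbon ring carries little weight here. The step of a 28-fold lower number from compound 2 to compound 3 (1.45 log units; beyond the scatter) shows that the 3-carboxypropoxy group is the outlier, and compound 4 keeps no oxygen link. Among the compounds with values here, no measured pair tells what shortening the acid arm by one carbon on the ring does, so that part remains open. The expected step of a 1.2-fold higher number from compound 3 to compound 4 (0.07 log units; within the scatter) is therefore small, with no clear direction beyond the scatter. Compound 4 is estimated at 50 nM, in the range 15 nM to 200 nM.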

Compound 4, inhibition constant: 43 nM
The estimate for compound 4 lay 1.2-fold (0.07 log units) above the measured number, and the stated range covers the measured number.
By their numbers in this assay, from the lowest: compounds 1, 3 and 4 (each within the scatter of the next); then compound 2.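

Placing the 3-carboxycyclopentyl group on the aromatic carbon para to a large group, in place of the open 4-carboxy-2-methylbutyl chain, gives no change at the digits printed from compound 3 to compound 4 (within the scatter) in this assay, so at this position the ring and the open chain cannot be told apart even when the ring bears the acid directly. The earlier compounds shown here left the length of the acid arm on the ring unresolved, and carboxy in place of carboxymethyl on a saturated ring carbon gives a 2.0-fold higher number from compound 1 to compound 4 (0.29 log units; within the scatter), so this shortening has no effect that can be read here. The 3-carboxypropoxy group of compound 2 stays apart from this third oxygen-free group as well, with a 28-fold lower number from compound 2 to compound 4 (1.45 log units; beyond the scatter), so the large gap now holds against two ring compounds and one open chain.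

The compounds shown leave open whether a six-membered carbon ring, a longer chain on the ring, or a tetrazole in place of the carboxylic acid would hold these numbers. No measurement here accounts for why the three oxygen-free groups give such similar numbers or why compound 2 stands so far from them.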